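The compounds below may be only part of what the source reports. "The series", "measured", "known", "first", "only" and "open" are said of these compounds alone.

In a functional assay on MCF7 cells (Homo sapiens) for antiproliferative activity (on this read-out lower numbers stand for stronger inhibition and higher numbers for weaker inhibition), compound 1 (`O=C1NC(O)C(F)=CN1[C@H]1C=C[C@@H](CO)O1`) gives 54100 nM as a measured number. Compound 2 (`Nc1nc(=O)n([C@H]2C=C[C@@H](CO)O2)cc1Br`) stands at > 100000 nM as a limit of the assay and not a number. Compound 3 (`Nc1nc(=O)n([C@H]2C=C[C@@H](CO)O2)cc1I`) departs from compound 2 in one place, with iodo in place of bromo on an aromatic carbon as the whole of the change, iodo in place of bromo on an aromatic carbon. Going by the values given here, no measured step between close neighbours is available yet, so the data offer no direct guide to this exchange. The estimated move a number no higher from compound 2 to compound 3 (the limit leaves the size open) is expected to stay within the usual scatter, with no particular direction foreseen. In this assay compound 3 is estimated at 100000 nM with an expected range from 45000 nM to 200000 nM and a good chance that it too ends up only as a limit.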

Compound 3, half-maximal inhibitory concentration: > 100000 nM
Compound 3: a limit, no number; the forecaster's own chance of this, stated with the estimate: 65%; the middle value sits exactly at the limit.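

Compound 2 and compound 3 both stand only as limits of the assay and not as numbers, so no step between them can be read: the limit of > 100000 nM in this assay, at which 2 of the 3 values shown sit.

The compounds shown leave open how iodo and bromo on this aromatic carbon compare in this assay.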